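Swapping Fluoro for Chloro on the Aniline Ring

The compounds below may be only part of what the source reports. "The series", "measured", "known", "first", "only" and "open" are said of these compounds alone.

In a functional assay on MCF7 cells (Homo sapiens) for antiproliferative activity, read by MTT assay, with a stated time of 48 h (a lower number here means a stronger inhibitor, a higher number a weaker inhibitor), compound 1 `O=C(/C=C/c1ccccc1)Nc1cc2ncnc(Nc3ccc(F)c(Cl)c3)c2s1` gives 30900 nM, the high end of the two numbers shown. Compound 2 `COc1ccc(/C=C/C(=O)Nc2cc3ncnc(Nc4ccc(F)c(Cl)c4)c3s2)cc1` gives 29100 nM in this assay, and the step of a 1.1-fold lower number from compound 1 to compound 2 (0.03 log units; within the scatter) lies within the scatter. Compound 3 `O=C(/C=C/c1ccccc1)Nc1cc2ncnc(Nc3ccc(Cl)c(Cl)c3)c2s1` differs from compound 1 by chloro in place of fluoro on an aromatic carbon. Among the compounds with values here, no measured step touches this place; the one measured step, methoxy in place of hydrogen, sits elsewhere and stayed within the scatter. Compound 3 is therefore expected at 30000 nM, with a range of 10000 nM to 90000 nM. The step of a 1.0-fold lower number from compound 1 to compound 3 (0.01 log units; within the scatter) is expected to remain within the scatter.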

Compound 3, half-maximal inhibitory concentration: > 100000 nM
Compound 3: only a limit was reported; the forecaster's own chance of this, stated with the estimate: 15%; middle value at least 3.3-fold (0.52 log units) away from the limit.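

In this assay, within the data shown here, this place on the 3-chloro-4-fluorophenyl group proves sensitive: chloro in place of fluoro gives an at least 3.2-fold higher number from compound 1 to compound 3 (0.51 log units; beyond the scatter), whereas the only earlier step, at another place, stayed within the scatter. Compound 3 reaches only a limit of the assay, so the full size of this step stays unread: the limit of > 100000 nM in this assay, at which 1 of the 3 values shown sits. The compounds shown leave open whether only chloro has this effect here, or whether hydrogen, a methyl group or an amine at the same place would also raise the number. They also leave open how far compound 3 lies beyond that limit.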